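Series notes: fluoro to hydrogen on the pendant phenyl

The compounds below may be only part of what the source reports. "The series", "measured", "known", "first", "only" and "open" are said of these compounds alone.

Measured so far:
compound 1 `COc1cc2ccc(=O)oc2cc1OC(=O)c1c(C)noc1-c1ccccc1F` gives > 25000 nM
compound 2 `COc1cc2ccc(=O)oc2cc1OC(=O)c1c(-c2ccc(Cl)cc2)n[nH]c1C` gives 13800 nM
compound 3 `COc1cc2ccc(=O)oc2cc1OC(=O)c1c(-c2ccccc2F)n[nH]c1C` gives > 25000 nM

For the measured compounds named here, in a functional assay on HCT-116 cells (Homo sapiens) for inhibition, read by MTT assay, with a stated time of 48 h (a higher number here means a weaker inhibitor, a lower number a stronger inhibitor), compound 2 gives 13800 nM and is the only compound of the three with a numerical result. For compound 1 the assay reports a limit, > 25000 nM. For compound 3 the assay likewise reports only a limit, > 25000 nM. Compound 3 therefore stands at the weak edge of what has been measured, at the limit of > 25000 nM in this assay, at which 2 of the 3 values shown sit. Going by the values given here, the single step between measured compounds that touches the aryl group is an at least 1.8-fold higher number from compound 2 to compound 3 (0.25 log units; that floor lies within the scatter); it fixes only a floor, and that floor is within the scatter, so it does not establish a direction.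

Compound 4 `COc1cc2ccc(=O)oc2cc1OC(=O)c1c(-c2ccccc2)n[nH]c1C` differs from compound 3 by hydrogen in place of fluoro on an aromatic carbon. Among the compounds with values here, no measured step removes a fluoro, so the expectation rests on compound 3 alone, whose result is a limit, and on the step from compound 2 to compound 3, which does not rise beyond the scatter. The expected step of a number no higher from compound 3 to compound 4 (the limit leaves the size open) is therefore small, with a fair chance that the assay again reports only a limit. The estimate for compound 4 in this assay is 25000 nM, with a range from 10000 nM to 60000 nM.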

Compound 4, half-maximal inhibitory concentration: > 25000 nM
Compound 4 ended at the assay's limit (the forecaster's own chance of this, stated with the estimate: 55%); the middle value sits exactly at the limit.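

Going from the 2-fluorophenyl to the plain phenyl group does not produce a numerical result: in this assay compound 4 gives > 25000 nM, a limit of the assay and not a number. The results for compound 3 and compound 4 are both limits, so the step between them cannot be read, and neither a gain nor a loss can be assigned to the fluoro at this place on the ring. Hydrogen in place of chloro gives an at least 1.8-fold higher number from compound 2 to compound 4 (0.25 log units; that floor lies within the scatter), so this pair, like the 2-fluorophenyl pair before it, is not shown to differ beyond the scatter, and the series now gathers at one edge of the measurable range: the limit of > 25000 nM in this assay, at which 3 of the 4 values shown sit.

With compound 2 still the only one of the four to carry a numerical result, no ranking of the groups on the pendant phenyl can be drawn from these compounds. From the compounds shown here alone, whether a methoxy group, a bromo group or an amine on that phenyl would give a readable number in this assay remains open.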